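A few compounds are considered here, and "the series" means these few. Any claim that something is new, unique, unknown or untested is made for them only; others in the source may bear on it.

Working notes on the series. Among the measured compounds shown here, compound 3 `C=CC[C@H]1C[C@]2([C@@H](C)Cc3cc(OC)c(OC)cc3F)OCOC2=CC1=O` gives 120 nM in a functional assay on NCI-H460 cells (Homo sapiens) for antiproliferative activity, with a stated time of 72 h (on this read-out higher numbers stand for weaker inhibition and lower numbers for stronger inhibition), the second highest of the three numbers so far; compound 2 `C=CC[C@H]1C[C@]2([C@@H](C)Cc3ccc(OC)cc3)OCOC2=CC1=O` gives 90 nM, within the scatter of compound 3, while compound 1 `C=CC[C@H]1C[C@]2([C@@H](C)Cc3ccc(OC)c(OC)c3)OCOC2=CC1=O` gives 260 nM, a step of a 2.2-fold lower number from compound 1 to compound 3 (0.34 log units; beyond the scatter) away.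

Compound 4 `C=CC[C@H]1C[C@]2([C@@H](C)Cc3cc(NC(C)=O)c(OC)cc3F)OCOC2=CC1=O` differs from compound 3 by acetamido in place of methoxy on an aromatic carbon. For the measured compounds named here, no measured pair swaps a methoxy for an acetamido, so the bearing of earlier steps is indirect. Going by the values given here, the nearest precedent is the removal of the methoxy at this same ring position, a 2.9-fold lower number from compound 1 to compound 2 (0.46 log units; beyond the scatter), a modest gain; the other step, a 2.2-fold lower number from compound 1 to compound 3 (0.34 log units; beyond the scatter), touches the fluoro and not this position. Taken together, these suggest that the group standing meta to the large group is not decisive for this assay, and that an exchange there is more likely to move the number by a small amount than by a large one, in either direction.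

For compound 4 a number close to that of compound 3 is therefore expected, with the step of a 1.1-fold lower number from compound 3 to compound 4 (0.04 log units; within the scatter) meaning little beyond the scatter. The estimate for compound 4 is 110 nM, with a range from 40 nM to 350 nM.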

Compound 4, half-maximal inhibitory concentration: 71 nM
Estimate against measurement, compound 4: 1.5-fold (0.19 log units) above; measured number inside the range.
By their numbers in this assay, from the lowest: compounds 4, 2 and 3 (each within the scatter of the next); then compound 1.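

In this assay the exchange of methoxy for acetamido gives a 1.7-fold lower number from compound 3 to compound 4 (0.23 log units; within the scatter). The earlier compounds shown here showed only the removal of a methoxy at this position, whereas compound 4 shows that a group with more heavy atoms and a hydrogen-bond donor can stand here, ortho to a methoxy group and para to a fluoro group, with compound 3 and compound 4 within the scatter of each other. Nothing available explains this result or links it to any measured property of the acetamido group.

Going by these compounds, how much further change this position accepts remains open: an amine or a carboxylic acid here, or a longer chain in place of the acetyl part of the acetamido, would help separate any contribution of the amide hydrogen from that of the carbonyl. Among the compounds shown here, also open is whether the same exchange reads alike on a ring without the fluoro group, as the single step available stands on a ring that carries it.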